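From hydroxy to propoxy on compound 3

The source may hold more compounds than are shown below. What is called first, only, known or untested is meant among the compounds shown, and "the series" means these compounds.

In a functional assay on KB cells (Homo sapiens) for antiproliferative activity, read by sulforhodamine B assay, with a stated time of 3 days (a lower number here means that less compound is needed, a higher number that more compound is needed for the effect), compound 1 (`CCC1=C(O)c2c(oc(-c3ccc(C)cc3)cc2=O)C(CC)(CC)C1=O`) gives 39.2 uM and compound 3 (`CCC1=C(O)c2c(oc(-c3ccc(O)cc3)cc2=O)C(CC)(CC)C1=O`) gives 20.6 uM so the two sit within the usual scatter of each other. For compound 2 (`CCCc1ccc(-c2cc(=O)c3c(o2)C(CC)(CC)C(=O)C(CC)=C3O)cc1`) the assay reports > 53 uM which is a limit and not a number. Only the gap to compound 2 sets compound 3 clearly apart, as the step of an at least 2.5-fold lower number from compound 2 to compound 3 (0.41 log units; beyond the scatter) shows.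

Compound 4 (`CCCOc1ccc(-c2cc(=O)c3c(o2)C(CC)(CC)C(=O)C(CC)=C3O)cc1`) differs from compound 3 at the hydroxy, which becomes propoxy (propyl in place of hydrogen on an oxygen on an aromatic ring). The closest measured change is hydroxy in place of propyl on an aromatic carbon (an at least 2.5-fold lower number from compound 2 to compound 3 (0.41 log units; beyond the scatter)) and it lies beyond the scatter. Hydroxy in place of methyl (a 1.9-fold lower number from compound 1 to compound 3 (0.28 log units; within the scatter)) stays within it. Among the measured compounds shown here, no measured compound carries propoxy, so these steps are only a rough guide. Read in reverse, they lead to an expected modest rise in this assay with the estimated step of a 1.9-fold higher number from compound 3 to compound 4 (0.29 log units; within the scatter) near the edge of the scatter. Compound 4 is estimated at 40 uM with a range from 20 uM to 75 uM in this assay.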

Compound 4, concentration for half-maximal effect: > 50.5 uM
Compound 4: only a limit was reported; the forecaster's own chance of this, stated with the estimate: 40%; at least 1.2-fold (0.10 log units) between middle value and limit.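

In this assay, putting propyl on the oxygen of the hydroxy group gives an at least 2.4-fold higher number from compound 3 to compound 4 (0.38 log units; beyond the scatter), and this is the only change shown that acts on that oxygen itself, so the free hydroxy now has a direct comparison with a capped one. Measured against the methyl group on the same aromatic carbon, propoxy gives an at least 1.2-fold higher number from compound 1 to compound 4 (0.11 log units; that floor lies within the scatter), so this second comparison does not separate the two groups on its own. Compound 4 is reported only as a limit: the limit of > 50.5 uM in this assay, at which 1 of the 4 values shown sits.

Compound 2 is a limit as well, so the step between these two limits cannot be read, and propoxy and propyl remain unranked. Going by these compounds, whether methoxy, a longer chain on the oxygen or an amine in place of the hydroxy would keep the number close to that of compound 3 remains open.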